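The source may hold more compounds than are shown below. What is called first, only, known or untested is meant among the compounds shown, and "the series" means these compounds.

Among the measured compounds shown here, in a functional assay on Huh-5-2 cells (Homo sapiens), read by MTT assay (on this read-out lower numbers stand for higher toxicity in this test and higher numbers for lower toxicity in this test), compound 3 (`O=C(O)c1ccc2c(c1)nc(-c1ccc(OCc3ccccc3-c3ccc(Cl)cc3)cc1)n2C1CCCCC1`) gives 25000 nM as the only true number in this small set. Compound 1 (`O=C(O)c1ccc(-c2ccc(Cl)cc2COc2ccc(-c3nc4cc(C(=O)O)ccc4n3C3CCCCC3)cc2)cc1`) stands at > 50000 nM as a limit and not a number. Compound 2 (`NC(=O)c1ccc(-c2ccc(Cl)cc2COc2ccc(-c3nc4cc(C(=O)O)ccc4n3C3CCCCC3)cc2)cc1`) stands at > 50000 nM as a limit too. For the measured compounds named here, the one measured step is therefore a step that the two limits leave unreadable from compound 1 to compound 2 and offers no size to carry over, with the limit of > 50000 nM in this assay, at which 2 of the 3 values shown sit, as all that it shows. Compound 4 (`CC(=O)c1ccc(-c2ccc(Cl)cc2)c(COc2ccc(-c3nc4cc(C(=O)O)ccc4n3C3CCCCC3)cc2)c1`) differs from compound 3 by one change (acetyl in place of hydrogen on an aromatic carbon) of acetyl in place of hydrogen on an aromatic carbon, para to a 4-chlorophenyl group. Going by the values given here, no measured step tests this change, so the expectation rests on compound 3 at 25000 nM alone. No step beyond the scatter is expected in this assay and no direction is favoured. The estimated step is a 1.1-fold higher number from compound 3 to compound 4 (0.05 log units; within the scatter) and no more. Compound 4 is expected at 28000 nM with an estimated range of 12000 nM to 50000 nM for now.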

Compound 4, half-maximal cytotoxic concentration: 24000 nM
For compound 4 the middle estimate is 1.2-fold (0.07 log units) above the measured one, and the stated range covers the measured number.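

In this assay, acetyl in place of hydrogen on an aromatic carbon, para to a 4-chlorophenyl group, gives a 1.0-fold lower number from compound 3 to compound 4 (0.02 log units; within the scatter). Among the compounds shown here, this is the first step in the set with a readable size, as the step from compound 1 to compound 2 cannot be read. At this position, the added acetyl leaves the number within the scatter of compound 3, and compound 4 gives a true number rather than a limit, while the limit still holds the remaining pair: the limit of > 50000 nM in this assay, at which 2 of the 4 values shown sit.

As far as these compounds go, whether an amine, a carboxylic acid or a longer acyl chain at this same position would also stay within the scatter remains open. This single step also says nothing about the other places on this ring.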